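The source may hold more compounds than are shown below. What is called first, only, known or untested is meant among the compounds shown, and "the series" means these compounds.

Compound 1 `Cc1ccc(Oc2ccc3nc(COc4cccc(C(=O)O)c4)n(C)c3n2)cc1`: 33 ug/mL
Compound 2 `Cn1c(COc2cccc(C(=O)O)c2)nc2cnc(Oc3ccc4c(c3)OCC4)cc21`: 79 ug/mL
Compound 3 `Cc1cccc(Oc2ccc3nc(COc4cccc(C(=O)O)c4)n(C)c3c2)n1`: 92 ug/mL

In a physicochemical assay for solubility, read by HPLC, measured as thermodynamic solubility, with a stated time of 4 h, at pH 6.8 (a higher number here means a more soluble compound, a lower number a less soluble compound), compound 3 gives 92 ug/mL, the highest of the three numbers shown. The value of compound 2 sits within the usual scatter of it, so no order can be read between those two; the value of compound 1 lies beyond the scatter and is clearly lower. Compound 4 `Cc1cc(F)cnc1Oc1ccc2nc(COc3cccc(C(=O)O)c3)n(C)c2c1` differs from compound 3 in one place: 5-fluoro-3-methylpyridin-2-yl in place of 6-methylpyridin-2-yl on an oxygen on an aromatic ring. Within the data shown here, no step between measured compounds covers a change of this kind, so there is no measured precedent to lean on. The step expected in this assay is small, with no clear direction beyond the scatter. The expected step is a 1.3-fold lower number from compound 3 to compound 4 (0.12 log units; within the scatter). Compound 4 is estimated at 70 ug/mL, with a range from 30 ug/mL to 160 ug/mL.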

Compound 4, solubility: 14 ug/mL
Compound 4: middle estimate off by 5.0-fold (0.70 log units), on the high side, outside the stated range (below it).
By their numbers in this assay, from the lowest: compound 4; then compound 1; then compounds 2 and 3 (each within the scatter of the next).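

In this assay, putting 5-fluoro-3-methylpyridin-2-yl in place of 6-methylpyridin-2-yl on the oxygen gives a 6.6-fold lower number from compound 3 to compound 4 (0.82 log units; beyond the scatter). The read-out is therefore sensitive to this position, even though both groups are one six-membered aromatic ring with 1 hetero atom and no net charge. No measurement shown here explains the drop.

The change moves the methyl and adds a fluorine in a single step, so the two cannot be separated. As far as these compounds go, whether 3-methylpyridin-2-yl, carrying no fluorine, would read closer to compound 3 or compound 4 stays open, as does the effect of an amine on this ring.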